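The source may hold more compounds than are shown below. What is called first, only, known or untested is meant among the compounds shown, and "the series" means these compounds.

Measured so far in this series: compound 1 `Cn1ncc2c(=O)n(-c3ccccc3)c(SC(C)(C)c3ccccc3)nc21` gives 1900 nM. Compound 2 `Cn1ncc2c(=O)n(-c3ccccc3)c(CNc3cccc(F)c3)nc21` gives 570 nM. Compound 3 `Cn1ccc2c(=O)n(-c3ccccc3)c(SCc3cccc(F)c3)nc21` gives 930 nM.

In an assay on isolated protein for inhibition of aldehyde dehydrogenase 1A1 (Homo sapiens) (a higher number here means a weaker inhibitor, a lower number a stronger inhibitor), compound 1 stands at the highest number of the three; the gap to compound 3 and the larger gap to compound 2 both lie beyond the usual scatter, so compound 1 is the weakest of the measured set.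

Compound 4 `CC(Sc1nc2c(cnn2C)c(=O)n1-c1ccccc1)c1cccnc1` is not yet measured. It differs from compound 1 in one place: 1-(pyridin-3-yl)ethyl in place of 1-methyl-1-phenylethyl on a sulfur. Within the data shown here, no single-point step between measured compounds exists to calibrate this change. Still, a modest step toward a lower number is expected, partly because compound 3 gives 930 nM with a related thioether. The expected step from compound 1 is a 1.9-fold lower number from compound 1 to compound 4 (0.28 log units; within the scatter). Compound 4 is accordingly estimated at 1000 nM, with a plausible range of 400 nM to 3000 nM.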

Compound 4, half-maximal inhibitory concentration: 139 nM
Compound 4: middle estimate off by 7.2-fold (0.86 log units), on the high side; measured number outside the range, below it.
By their numbers in this assay, from the lowest: compound 4; then compounds 2 and 3 (each within the scatter of the next); then compound 1.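

In this assay the group on the sulfur proves a strong lever: 1-(pyridin-3-yl)ethyl in place of 1-methyl-1-phenylethyl gives a 14-fold lower number from compound 1 to compound 4 (1.14 log units; beyond the scatter) with the rest of the structure unchanged. Among these compounds, the earlier compounds offered no comparison in one place, so this is the first direct reading of this position, and it shows that the series responds strongly to this change.

The swap alters the aromatic ring and the carbon on the sulfur together, so a 1-phenylethyl group there would be needed to separate the two. No measurement at hand explains the step.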